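The source may hold more compounds than are shown below. What is called first, only, known or untested is meant among the compounds shown, and "the series" means these compounds.

Measured in a functional assay on DU-145 cells (Homo sapiens) for inhibition, read by trypan blue exclusion, with a stated time of 96 h; on this read-out higher numbers stand for weaker inhibition of growth and lower numbers for stronger inhibition of growth:

- compound 1 `Cc1ccc(CS/C(=C/c2ccc(O)cc2)C(=O)c2ccc(Cl)cc2)cc1` gives 10000 nM
- compound 2 `Cc1ccc(CS/C(=C/c2c(O)cc(O)cc2O)C(=O)c2ccc(Cl)cc2)cc1` gives 50000 nM
- compound 3 `O=C(/C(=C\c1c(O)cc(O)cc1O)S(=O)(=O)c1ccccc1Br)c1ccc(Cl)cc1` gives 50000 nM

Compound 2 stands level with compound 3, and both carry a higher number than compound 1, a gap beyond the scatter. The change followed here leads from compound 2 to compound 4 `Cc1ccc(CS/C(=C/c2cc(C)ccc2C)C(=O)c2ccc(Cl)cc2)cc1`: 2,5-dimethylphenyl in place of 2,4,6-trihydroxyphenyl on a double-bonded chain carbon bound to a double-bonded chain carbon. The closest evidence is the step at the same place, a 5.0-fold higher number from compound 1 to compound 2 (0.70 log units; beyond the scatter). Compound 1 and compound 2 both carry hydroxyl groups on this ring, so that step only partly resembles the new change. The other step, no change at the digits printed from compound 2 to compound 3 (within the scatter), lies at a different place and says little about this one. Going by the values given here, no measured compound carries 2,5-dimethylphenyl, so the expectation is uncertain. In this assay a modest move towards a lower number is expected, of about the size seen between compound 1 and compound 2, though no change remains possible. The expected change is an estimated 5.0-fold lower number from compound 2 to compound 4 (0.70 log units; beyond the scatter). For compound 4 the estimated value is 10000 nM, with an expected range from 2500 nM to 40000 nM.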

Compound 4, concentration for 50% growth inhibition: 10000 nM
The estimate for compound 4 equals the measured number at the digits printed, within the range that was stated.
By their numbers in this assay, from the lowest: compounds 1 and 4 (each within the scatter of the next); then compounds 2 and 3 (each within the scatter of the next).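

In this assay, compound 4 is the first compound shown with no hydroxyl on this ring, and the change to 2,5-dimethylphenyl gives a 5.0-fold lower number from compound 2 to compound 4 (0.70 log units; beyond the scatter). Against the 4-hydroxyphenyl group, the same change gives no change at the digits printed from compound 1 to compound 4 (within the scatter), so among these three rings a hydroxyl is not required for the lower number, and only the 2,4,6-trihydroxyphenyl ring carries the higher one. Nothing measured here bears on why these rings read as they do.

From the compounds shown here alone, it remains open whether the methyl groups themselves matter or whether removing the hydroxyl groups from the 2,4,6-trihydroxyphenyl ring is enough, and how a methoxy group or an amine on this ring would read. Also open, going by these compounds, is whether 2,5-dimethylphenyl would give a similar step alongside the (2-bromophenyl)sulfonyl group of compound 3.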